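Notes on the 4-methylphenyl analogue of compound 2

A few compounds are considered here, and "the series" means these few. Any claim that something is new, unique, unknown or untested is made for them only; others in the source may bear on it.

- Compound 1 `COc1cc2c(Oc3ccc(NC(=O)c4nn(-c5ccccc5C)cc(C)c4=O)cc3)ccnc2cc1OCCCC(=O)NO`: 4460 nM
- Compound 2 `COc1cc2c(Oc3ccc(NC(=O)c4nn(-c5ccc(F)c(Cl)c5)cc(C)c4=O)cc3)ccnc2cc1OCCCCCCC(=O)NO`: 380 nM
- Compound 3 `COc1cc2c(Oc3ccc(NC(=O)c4nn(-c5ccccc5)cc(C)c4=O)cc3F)ccnc2cc1OCCCCCC(=O)NO`: 4170 nM

In a functional assay on A549 cells (Homo sapiens) for inhibition, read by MTT assay, with a stated time of 72 h (a lower number here means a stronger inhibitor, a higher number a weaker inhibitor), compound 2 gives 380 nM, the lowest of the three numbers, with compound 1 and compound 3 both higher by more than the scatter. Compound 4 `COc1cc2c(Oc3ccc(NC(=O)c4nn(-c5ccc(C)cc5)cc(C)c4=O)cc3)ccnc2cc1OCCCCCCC(=O)NO` carries 4-methylphenyl in place of 3-chloro-4-fluorophenyl on an aromatic nitrogen. No two measured compounds differ in one place only, so the effect of this change has not been shown directly and the expectation is loose. The expected step of a 1.7-fold higher number from compound 2 to compound 4 (0.23 log units; within the scatter) in this assay is small, toward a higher number, and about the size of the scatter. The estimate for compound 4 is 650 nM, with an expected range of 200 nM to 2000 nM.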

Compound 4, half-maximal inhibitory concentration: 160 nM
Beside the measured number, compound 4's estimate is 4.1-fold (0.61 log units) above it; measured number outside the range, below it.
By their numbers in this assay, from the lowest: compound 4; then compound 2; then compounds 3 and 1 (each within the scatter of the next).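

This pair gives the series its first single-place comparison: on the aromatic nitrogen, 4-methylphenyl in place of 3-chloro-4-fluorophenyl gives a 2.4-fold lower number from compound 2 to compound 4 (0.38 log units; beyond the scatter) in this assay. At this position, neither the chlorine nor the fluorine of compound 2 is needed to reach a lower number. Nothing available explains the step.

Going by these compounds, whether the step follows from losing the halogens or from gaining the methyl remains open. A 4-chlorophenyl or 4-methoxyphenyl group on this nitrogen, with the rest of compound 4 unchanged, would help separate these possibilities.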